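Halogen swap on the shared core: compound 4 projected

The source may hold more compounds than are shown below. What is called first, only, known or untested is meant among the compounds shown, and "the series" means these compounds.

Measured compounds in a functional assay on the whole organism (strain albino) with Mus musculus as the target, in the maximal electroshock model, with a stated time of 0.5 h; a higher number here means that more compound is needed for the effect, a lower number that less compound is needed:
- compound 1, `Cc1ccccc1Nc1nnc(Nc2nc(-c3ccc(Cl)cc3)cs2)s1`: 300 mg/kg
- compound 2, `Cc1ccc(Nc2nnc(Nc3nc(-c4ccc(Cl)cc4)cs3)s2)cc1`: 300 mg/kg
- compound 3, `COc1ccc(Nc2nnc(Nc3nc(-c4ccc(Cl)cc4)cs3)s2)cc1`: 100 mg/kg

Compound 1 stands level with compound 2 at the digits given, and together they carry the highest numbers of the three; compound 3 sits lowest, with a 3.0-fold lower number from compound 1 to compound 3 (0.48 log units; beyond the scatter) and a 3.0-fold lower number from compound 2 to compound 3 (0.48 log units; beyond the scatter) both beyond the scatter, while no change at the digits printed from compound 1 to compound 2 (within the scatter) is within it.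

Compound 4, `Cc1ccccc1Nc1nnc(Nc2nc(-c3ccc(Br)cc3)cs2)s1`, is not yet measured. It differs from compound 1 as follows: bromo in place of chloro on an aromatic carbon. Among the measured compounds shown here, none of the measured steps touches this position: every step among compounds 1, 2 and 3 alters the aryl group on the ring nitrogen, and the 4-chlorophenyl is held constant throughout. For the measured compounds named here, no measured step therefore bears directly on the change to compound 4, and the expected step in this assay is none beyond the scatter.

Compound 4 is accordingly expected to give about 300 mg/kg, within a range of 100 mg/kg to 600 mg/kg, which means an estimated step of no change at the digits printed from compound 1 to compound 4 (within the scatter).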

Compound 4, minimum effective dose: 300 mg/kg
Compound 4: the middle estimate sits on the measured number at the digits printed; the measured number falls inside the stated range.
By their numbers in this assay, from the lowest: compound 3; then compounds 1, 2 and 4 (each within the scatter of the next).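

In this assay, 4-bromophenyl in place of 4-chlorophenyl gives no change at the digits printed from compound 1 to compound 4 (within the scatter). Among the compounds shown here, this is the first reading at this position, as the earlier steps all altered the aryl group on the nitrogen and left the 4-chlorophenyl untouched. With the 2-methylphenyl group held, the position therefore accepts bromo in place of chloro without a step beyond the scatter, though this rests on a single pair, and nothing at hand offers an explanation for the result.

From the compounds shown here alone, it remains open whether the same exchange would read alike with the 4-methoxyphenyl group of compound 3, which gives 100 mg/kg. Also open, going by these compounds, is whether something other than chloro or bromo at this position, such as an amine, a carboxylic acid or a longer alkyl chain, would move the number beyond the scatter.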